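One Stereocentre Redrawn on a Saturated Chain

The source may hold more compounds than are shown below. What is called first, only, known or untested is meant among the compounds shown, and "the series" means these compounds.

- Compound 1 `C[C@@H](CCCN1CCN(C)CC1)Nc1ccnc2cc(Cl)ccc12` gives 140000 nM
- Compound 2 `CCN(C)CCC[C@@H](C)Nc1ccnc2cc(Cl)ccc12` gives 140000 nM

In an assay for binding affinity, read by spectrophotometry (a lower number here means a stronger inhibitor, a higher number a weaker inhibitor), compound 2 gives 140000 nM and stands level with compound 1 (140000 nM), within the usual scatter of repeated measurements.

Compound 3 `CCN(C)CCC[C@H](C)Nc1ccnc2cc(Cl)ccc12` has the same atoms and bonds as compound 2 and differs only in configuration as drawn (the two compounds have the same atoms and bonds and differ only in configuration as drawn: 1 of 1 stereo elements differ; a stereocentre at a saturated chain carbon is drawn R in compound 2 and S in compound 3): a stereocentre at a saturated chain carbon is drawn R in compound 2 and S in compound 3. For the measured compounds named here, no measured pair here shows what such a redrawing does in this assay, so the forecast stays close to the starting value, with no direction favoured. The expected step is no change at the digits printed from compound 2 to compound 3 (within the scatter) (none beyond the scatter). For compound 3 the estimated value is 140000 nM (expected range 70000 nM to 280000 nM).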

Compound 3, half-maximal inhibitory concentration: 150000 nM
For compound 3 the middle estimate is 1.1-fold (0.03 log units) below the measured one, within the range that was stated.
By their numbers in this assay, from the lowest: compounds 1, 2 and 3 (each within the scatter of the next).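

In this assay, redrawing the stereocentre at the saturated chain carbon from R to S gives a 1.1-fold higher number from compound 2 to compound 3 (0.03 log units; within the scatter), so the two drawn configurations cannot be told apart by this read-out. Swapping the end group gives the same picture, with ethyl(methyl)amino in place of 4-methylpiperazin-1-yl giving a 1.1-fold higher number from compound 1 to compound 3 (0.03 log units; within the scatter). This is the first pair to isolate configuration, and nothing else in the structure can blur the comparison: the fact that compounds 2 and 3 differ only in the configuration as drawn

As far as these compounds go, all three compounds are weak inhibitors here, so it remains open whether configuration at this carbon would matter in a compound with a much lower number. A longer chain, or a primary amine in place of ethyl(methyl)amino, might show whether this chain can move the value at all.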